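A 4-bromobutyl group after two limit readings

The source may report more compounds than this note shows. Statements on the series, on what has been measured and on what is new or still open speak of the compounds shown alone.

Compound 1 `C=C1C(=O)O[C@H]2CC3=C[C@H](C/C(C)=C/[C@@H](OC(=O)c4ccc([N+](=O)[O-])cc4)[C@H]12)OC3=O`: > 10000 nM (a limit)
Compound 2 `C=C1C(=O)O[C@H]2CC3=C[C@H](C/C(C)=C/[C@@H](OC(=O)/C=C/c4cccc(OC)c4)[C@H]12)OC3=O`: > 10000 nM (a limit)

Both compounds were read in a functional assay on NCI-H460 cells (Homo sapiens) for cytotoxicity, read by MTT assay, with a stated time of 48 h; a higher number here means a weaker inhibitor, a lower number a stronger inhibitor. Compound 2 reads > 10000 nM and this is a limit of the assay and not a number. The whole record is the limit of > 10000 nM in this assay, at which 2 of the 2 values shown sit, and it gives no measured value to start from. Compound 3 `C=C1C(=O)O[C@H]2CC3=C[C@H](C/C(C)=C/[C@@H](OC(=O)CCCCBr)[C@H]12)OC3=O` has 4-bromobutyl in place of 2-(3-methoxyphenyl)ethenyl on a carbonyl carbon. Among the compounds with values here, the one measured step at this place is a step that the two limits leave unreadable from compound 1 to compound 2 and it offers no size and no direction to carry over. The expected move is therefore only weakly founded, an estimated at least 1.1-fold lower number from compound 2 to compound 3 (0.04 log units; that floor lies within the scatter) with no firm direction. For compound 3 the estimated value is 9000 nM (3000 nM to 27000 nM).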

Compound 3, half-maximal inhibitory concentration: > 10000 nM
Compound 3 was reported as a limit (the forecaster's own chance of this, stated with the estimate: 55%); middle value at least 1.1-fold (0.04 log units) away from the limit.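

Compound 3 reads > 10000 nM and this is a limit. Its steps from compound 1 and compound 2 therefore cannot be read: the limit of > 10000 nM in this assay, at which 3 of the 3 values shown sit. The compounds shown leave open how the 4-bromobutyl, 2-(3-methoxyphenyl)ethenyl and 4-nitrophenyl groups compare, with no measured number among them.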